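The source may hold more compounds than are shown below. What is called first, only, known or untested is meant among the compounds shown, and "the series" means these compounds.

Series notes. Compound 1 `CCN(CC)S(=O)(=O)c1ccc(S(=O)(=O)N2CCC[C@@H](C(=O)NC3CN(C(=O)OC(C)(C)C)C3)C2)cc1` carries the 1-(tert-butoxycarbonyl)azetidin-3-yl group on an amide-type nitrogen. In a functional assay on MIA PaCa-2 cells (Homo sapiens) for inhibition, read by MTT assay, with a stated time of 3 days (a higher number here means a weaker inhibitor, a lower number a stronger inhibitor), compound 1 gives > 10000 nM, which is a limit of the assay and not a number. Compound 2 `CC(C)c1noc(N2CCN(C(=O)[C@@H]3CCCN(S(=O)(=O)c4ccc(S(=O)(=O)C(C)C)cc4)C3)CC2)n1` in this assay gives > 10000 nM, again only a limit. Compound 3 `CCOC(=O)[C@@H]1CCCN(S(=O)(=O)c2cccc(S(=O)(=O)N(CC)CC)c2)C1` in this assay gives > 10000 nM, also a limit. Going by the values given here, compound 1 thus stands at the limit of > 10000 nM in this assay, at which 3 of the 3 values shown sit, and no measured step within the set shows how a change at the amide-type nitrogen moves potency.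

Compound 4 `CCN(CC)S(=O)(=O)c1ccc(S(=O)(=O)N2CCC[C@@H](C(=O)N[C@H]3CCN(C(=O)OC(C)(C)C)C3)C2)cc1` differs from compound 1 by 1-(tert-butoxycarbonyl)pyrrolidin-3-yl in place of 1-(tert-butoxycarbonyl)azetidin-3-yl on an amide-type nitrogen. The change is modest: a five-membered non-aromatic ring with one defined stereocentre in place of a four-membered non-aromatic ring on the amide-type nitrogen, the tert-butoxycarbonyl group kept. Compound 1 sits only at a limit, > 10000 nM. The step that the limit leaves unreadable from compound 1 to compound 4 is therefore expected to be none beyond the scatter. Compound 4 is estimated at 15000 nM, with a range from 5000 nM to 50000 nM, and is expected most likely to return only a limit as well.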

Compound 4, half-maximal inhibitory concentration: > 10000 nM
Compound 4 was reported as a limit; the forecaster's own chance of this, stated with the estimate: 85%; the middle value does not contradict the limit.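

In this assay, going by these compounds alone, compound 4 gives > 10000 nM which is a limit of the assay and not a number; compound 1 also stands only at a limit, so no step between compound 1 and compound 4 can be read. The compounds shown leave open whether any change on the amide-type nitrogen moves potency, with every reading resting on one value: the limit of > 10000 nM in this assay, at which 4 of the 4 values shown sit.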